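Title: A spirocyclic swap on the shared core and expected solubility

This account rests on a few compounds, and the source may have more. Where it says the series, first, only, none or still open, it means among the compounds named here.

The study follows a small set of amides built on a shared core. Compound 1 `COc1ccc2[nH]c(C(=O)N3CC(=O)N(Cc4ccccc4)[C@@H](CCN4CCC5(CC4)CC5)C3)cc2c1` was tested in a physicochemical assay for solubility, read by spectrophotometry, in phosphate buffer, with a stated time of 2 h, at pH 7.4; a higher number here means a more soluble compound, a lower number a less soluble compound. In this assay compound 1 gives > 25000 nM, which is a limit of the assay and not a number; it is the point (the limit of > 25000 nM in this assay, at which 1 of the 3 values shown sits). Two other compounds on the same core were measured as numbers. Compound 2 `COc1ccc2[nH]c(C(=O)N3CC(=O)N(Cc4ccccc4)[C@@H](CN4CCN(c5ccc(F)cc5)CC4)C3)cc2c1` gives 20700 nM in this assay. Compound 3 `COc1ccc2[nH]c(C(=O)N3CC(=O)N(Cc4cccc(OC(F)F)c4)[C@@H](CN4CCN(C5CC5)CC4)C3)cc2c1` gives 99600 nM in this assay. Compound 4 `COc1ccc2[nH]c(C(=O)N3CC(=O)N(Cc4ccccc4)[C@@H](CN4CC5(CCC5)C4)C3)cc2c1` has not yet been measured. It differs from compound 1 in one place: a group of 7 heavy atoms (6 carbon, 1 nitrogen; one four-membered non-aromatic ring of carbon only, one four-membered non-aromatic ring with 1 hetero atom) in place of a group of 9 heavy atoms (8 carbon, 1 nitrogen; one three-membered non-aromatic ring of carbon only, one six-membered non-aromatic ring with 1 hetero atom), on a saturated chain carbon bound to a saturated ring carbon. Going by the values given here, no step between two measured compounds is available for this change, so the size of the step from compound 1 to compound 4 in this assay cannot be read from a measured pair. The author expects the step that the limit leaves unreadable from compound 1 to compound 4 to be small, either none beyond the scatter or a modest move toward higher solubility, since compound 1 already sits at the limit (the limit of > 25000 nM in this assay, at which 1 of the 3 values shown sits). For compound 4 the estimated solubility in this assay is 60000 nM, with a range from 20000 nM to 200000 nM.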

Compound 4, solubility: 60700 nM
For compound 4 the middle estimate is 1.0-fold (0.01 log units) below the measured one; low and high end bracket the measured number.
By their numbers in this assay, from the lowest: compound 2; then compounds 4 and 3 (each within the scatter of the next).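

No new step can be read from compound 1 to compound 4 in this assay, because the value for compound 1 is a limit of the assay and not a number: the limit of > 25000 nM in this assay, at which 1 of the 4 values shown sits.

The compounds shown leave open how large a step this swap of groups gives on the shared core.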